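Losing the Dimethylamino Chain: From Compound 3 to Compound 4

The compounds below may be only part of what the source reports. "The series", "measured", "known", "first", "only" and "open" are said of these compounds alone.

Measured so far in a functional assay on A-375 cells (Homo sapiens) for cytotoxicity, read by MTT assay; on this read-out lower numbers stand for stronger inhibition and higher numbers for weaker inhibition (the first two entries are limits of the assay, not numbers):
- compound 1 `COc1ccc(/C=C/C(=O)c2ccc(OC)c3c2OC(C)(C)C=C3)cc1OCC=C(C)C` gives > 10000 nM
- compound 2 `C=CCOc1cc(/C=C/C(=O)c2ccc(OC)c3c2OC(C)(C)C=C3)ccc1OC` gives > 10000 nM
- compound 3 `COc1ccc(/C=C/C(=O)c2ccc(OC)c3c2OC(C)(C)C=C3)cc1OCCCN(C)C` gives 4100 nM

Among the compounds with values here, compound 3 holds the only true number in this small set. Within the data shown here, compound 1 and compound 2 rest at the limit of > 10000 nM in this assay, at which 2 of the 3 values shown sit, and offer only that limit for comparison.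

Compound 4 `COc1cccc(C(=O)Oc2cc(/C=C/C(=O)c3ccc(OC)c4c3OC(C)(C)C=C4)ccc2OC)c1` has (3-methoxyphenyl)carbonyl in place of 3-(dimethylamino)propyl on an oxygen on an aromatic ring and so loses the dimethylamino group.

Among the measured compounds shown here, two measured steps bear on this change. One is an at least 2.4-fold lower number from compound 1 to compound 3 (0.38 log units; beyond the scatter) and the other is an at least 2.4-fold lower number from compound 2 to compound 3 (0.38 log units; beyond the scatter), and each gained a dimethylamino group. The third, a step that the two limits leave unreadable from compound 1 to compound 2, gives no guidance. Compound 4 carries a different group from compound 1 and compound 2, so they are only a loose guide, but the direction expected in this assay is toward a higher number, meaning weaker inhibition. The expected change is a 2.4-fold higher number from compound 3 to compound 4 (0.39 log units; beyond the scatter), and a result reported only as a limit would be no surprise. For compound 4 the estimated value is 10000 nM, with an expected range from 3500 nM to 30000 nM.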

Compound 4, half-maximal inhibitory concentration: 800 nM
The estimate for compound 4 lay 13-fold (1.10 log units) above the measured number, outside the stated range (below it).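

In this assay, the dimethylamino group turns out not to be needed for activity at this oxygen on an aromatic ring: exchanging 3-(dimethylamino)propyl for (3-methoxyphenyl)carbonyl, a group without nitrogen, gives a 5.1-fold lower number from compound 3 to compound 4 (0.71 log units; beyond the scatter). Within the data shown here, until now, the only number in the set belonged to the one compound bearing an amine, whereas this change places an aromatic ring and a carbonyl at the same oxygen and gives the stronger result, with an at least 12-fold lower number from compound 2 to compound 4 (1.09 log units; beyond the scatter) and an at least 12-fold lower number from compound 1 to compound 4 (1.09 log units; beyond the scatter), so compound 4 is the most potent of the four. Those two larger steps are bounds rather than exact sizes, as compound 1 and compound 2 each rest on a limit and not on a number: the limit of > 10000 nM in this assay, at which 2 of the 4 values shown sit.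

The carbonyl and the 3-methoxyphenyl ring enter together, so the compounds shown do not separate their contributions; a 3-methoxybenzyl group without the carbonyl, or a plain acetyl group without the ring, would pull them apart. As far as these compounds go, whether the methoxy group matters also stays open, and an unsubstituted benzoyl group would address that question.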